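Working notes: 4-methylpiperazin-1-yl replacing 4-chloropiperidin-1-yl

The source may hold more compounds than are shown below. What is called first, only, known or untested is meant among the compounds shown, and "the series" means these compounds.

In a functional assay on MGC-803 cells (Homo sapiens) for cytotoxicity, read by MTT assay, with a stated time of 48 h (a lower number here means a stronger inhibitor, a higher number a weaker inhibitor), compound 1 `CC1=NN(C(=O)COc2ccc(Cl)cc2)C(c2ccccc2O)C1` is reported as "not active" (no number reported) with no number. Within the data shown here, compound 2 `CC1=NN(C(=O)CN2CCC(Cl)CC2)C(c2ccccc2O)C1` gives 30300 nM and is the only numeric value so far. Compound 3 `CC1=NN(C(=O)CN2CCN(C)CC2)C(c2ccccc2O)C1` is the next entry. The change 4-methylpiperazin-1-yl in place of 4-chloropiperidin-1-yl on a saturated chain carbon bound to a carbonyl carbon places 4-methylpiperazin-1-yl in place of 4-chloropiperidin-1-yl on a saturated chain carbon bound to a carbonyl carbon. Among the measured compounds shown here, no measured step is available as a guide, so in this assay no shift beyond the scatter is expected in either direction. The expected step of a 1.2-fold lower number from compound 2 to compound 3 (0.08 log units; within the scatter) is small. Compound 3 is estimated at 25000 nM with an expected range from 8000 nM to 80000 nM in this series.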

Compound 3, half-maximal inhibitory concentration: 7850 nM
Compound 3: middle estimate off by 3.2-fold (0.50 log units), on the high side; measured number below the stated range.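

Among these compounds, the step of a 3.9-fold lower number from compound 2 to compound 3 (0.59 log units; beyond the scatter) in this assay is the first measured change at this position, on a saturated chain carbon bound to a carbonyl carbon. It shows that the number responds to the group placed there, even though 4-chloropiperidin-1-yl and 4-methylpiperazin-1-yl have the same heavy-atom count and both are six-membered non-aromatic rings. Nothing available explains the step.

Among the compounds shown here, the single step cannot separate the loss of the chlorine from the entry of the second ring nitrogen and its methyl. Unsubstituted piperidin-1-yl or morpholin-4-yl at this place would bear on that question.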